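This account rests on a few compounds, and the source may have more. Where it says the series, first, only, none or still open, it means among the compounds named here.

In a functional assay on CaEs17 cells (Homo sapiens) for cytotoxicity, read by MTT assay, with a stated time of 72 h (a lower number here means a stronger inhibitor, a higher number a weaker inhibitor), compound 1 (`C=C1C(=O)[C@@]23C(=O)OC[C@]4(C(=O)CCC(C)(C)[C@H]4C=O)[C@@H]2CC[C@@H]1[C@H]3OC(C)=O`) gives 1350 nM, compound 2 (`C=C1C(=O)[C@@]23C(=O)OC[C@]4(C(=O)CCC(C)(C)[C@H]4C=O)[C@@H]2CC[C@@H]1[C@H]3OC(=O)c1ccc(C)cc1`) gives 1050 nM, and compound 3 (`C=C1C(=O)[C@@]23C(=O)OC[C@]4(C(=O)CCC(C)(C)[C@H]4C=O)[C@@H]2CC[C@@H]1[C@H]3OC(=O)c1ccc(C(F)(F)F)cc1`) gives 8960 nM, the highest number of the three. Compound 4 (`C=C1C(=O)[C@@]23C(=O)OC[C@]4(C(=O)CCC(C)(C)[C@H]4C=O)[C@@H]2CC[C@@H]1[C@H]3OC(=O)c1ccc(Cl)cc1`) carries chloro in place of trifluoromethyl on an aromatic carbon, para to a large group: chloro in place of trifluoromethyl on an aromatic carbon. The closest measured precedent is the exchange of methyl for trifluoromethyl at the same place, which gave an 8.5-fold higher number from compound 2 to compound 3 (0.93 log units; beyond the scatter). The other steps are a 6.6-fold higher number from compound 1 to compound 3 (0.82 log units; beyond the scatter) and a 1.3-fold lower number from compound 1 to compound 2 (0.11 log units; within the scatter). For the measured compounds named here, no chloro compound has been measured, so only a partial return towards the lower numbers is expected, with the estimated step being a 3.6-fold lower number from compound 3 to compound 4 (0.55 log units; beyond the scatter). Compound 4 is expected at 2500 nM, within an estimated range of 900 nM to 7000 nM.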

Compound 4, half-maximal inhibitory concentration: 2550 nM
The estimate for compound 4 lay 1.0-fold (0.01 log units) below the measured number; measured number inside the range.
By their numbers in this assay, from the lowest: compounds 2, 1 and 4 (each within the scatter of the next, the first and the last beyond it); then compound 3.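

In this assay chloro on the aromatic carbon para to a large group recovers much of the loss seen with trifluoromethyl (a 3.5-fold lower number from compound 3 to compound 4 (0.55 log units; beyond the scatter)). Recovery is not complete against methyl on the same carbon (a 2.4-fold higher number from compound 2 to compound 4 (0.39 log units; beyond the scatter)), while the 4-chlorophenyl ester stays within the scatter of the acetyl ester (a 1.9-fold higher number from compound 1 to compound 4 (0.28 log units; within the scatter)), so the numbers at this place run methyl, chloro, trifluoromethyl from lowest to highest. No measurement at hand accounts for this order.

As far as these compounds go, how an amine, a methoxy group or a carboxylic acid at this place would read remains open, as does whether fluoro or bromo would track chloro.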